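This account rests on a few compounds, and the source may have more. Where it says the series, first, only, none or still open, it means among the compounds named here.

Measured compounds:
compound 1, `CC(C)(C)CNC(=O)c1ccc(C#Cc2cccc(F)c2)cn1` — in a functional assay on HEK293 cells for positive allosteric modulation of metabotropic glutamate receptor 5 (Rattus norvegicus), read by fluorescence and calcium flux (a lower number here means a smaller maximal response, a higher number a larger maximal response), compound 1 gives 63.9%
compound 2, `CC(C)(CO)NC(=O)c1ccc(C#Cc2cccc(F)c2)cn1` — compound 2 gives 60.9%

Within the data shown here, compound 2 holds the lower of the two numbers, and its nearest neighbour is compound 1; the only measured step, a number 3 percentage points lower from compound 1 to compound 2 (within the scatter), lies within the scatter, so the two values are treated as equal.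

Compound 3, `CC(C)(O)CNC(=O)c1ccc(C#Cc2cccc(F)c2)cn1`, shares the core of compound 2 and differs from it only in the group on the amide-type nitrogen: 2-hydroxy-2-methylpropyl in place of 1-(hydroxymethyl)-1-methylethyl on an amide-type nitrogen. Among the measured compounds shown here, no measured step swaps these two groups directly. For the measured compounds named here, the one step that bears on the place at all is the exchange of neopentyl for 1-(hydroxymethyl)-1-methylethyl on the same nitrogen, which changed the maximal response by a number 3 percentage points lower from compound 1 to compound 2 (within the scatter), that is, not beyond the scatter. On that basis compound 3 is expected to stay close to compound 2, with a step of about a number 0.9 percentage points lower from compound 2 to compound 3 (within the scatter) that does not exceed the scatter. The estimated value for compound 3 is 60%, with a range from 46% to 74%.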

Compound 3, largest response reached (reported as efficacy), in percent of the reference or control that the assay uses: 61.5%
Beside the measured number, compound 3's estimate is 1.5 percentage points below it; the measured number falls inside the stated range.
By their numbers in this assay, from the lowest: compounds 2, 3 and 1 (each within the scatter of the next).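

In this assay, 2-hydroxy-2-methylpropyl in place of 1-(hydroxymethyl)-1-methylethyl on the amide-type nitrogen gives a number 0.6 percentage points higher from compound 2 to compound 3 (within the scatter), so two groups with the same atoms, joined differently, are not told apart by the maximal response. Hydroxy in place of methyl on a saturated chain carbon bound to three saturated chain carbons gives a number 2.4 percentage points lower from compound 1 to compound 3 (within the scatter), a second exchange at this position that stays inside the scatter, and so the three side chains shown, with or without a hydroxy, cannot be ranked. Nothing is available here that would account for these values.

As far as these compounds go, whether the maximal response stays this level with an amine or a carboxylic acid on the chain, or with a longer chain on the same nitrogen, remains open. The three compounds also share one core and are compared only by their largest response, so they leave open whether the concentration needed to reach that response differs among these side chains.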